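The source may report more compounds than this note shows. Statements on the series, on what has been measured and on what is new or still open speak of the compounds shown alone.

Measured so far: compound 1 `COc1ccc(/C=C2\CN(CC(=O)O)c3c(Cl)cccc3C2=O)c(OC)c1OC` with 23.6%; compound 2 `COc1cccc(/C=C2\CN(CC(=O)O)c3c(C)cccc3C2=O)c1OC` with 8.1%.

In an assay on HL-60 cells for inhibition of glutathione S-transferase P (Homo sapiens), read by spectrophotometry, tested at 20 uM (a higher number here means more inhibition at the concentration tested (going by the name of the read-out), a lower number less inhibition), compound 2 gives 8.1%, the lowest of the two numbers; the nearest is compound 1, which stands higher by a gap beyond the scatter. Compound 3 `COc1ccc(/C=C2\CN(CC(=O)O)c3c(C)cccc3C2=O)c(OC)c1OC` has not been measured. The change from compound 2 to compound 3 is methoxy in place of hydrogen on an aromatic carbon. Since compound 1, which also carries the trimethoxy pattern, reaches 23.6%, a modest rise in this assay is expected for compound 3, though it keeps a different group on the core. Compound 3 is expected to give 16%, between 5% and 30%. The expected step is a number 7.9 percentage points higher from compound 2 to compound 3 (within the scatter).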

Compound 3, a percentage reported as inhibition, at one concentration (the size of the read-out at that concentration, not a potency): 1.57%
For compound 3 the middle estimate is 14.4 percentage points above the measured one; measured number outside the range, below it.
By their numbers in this assay, from the lowest: compounds 3 and 2 (each within the scatter of the next); then compound 1.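

In this assay methoxy in place of hydrogen on this aromatic carbon gives a number 6.5 percentage points lower from compound 2 to compound 3 (within the scatter) and so, with methyl on the core, this position shows no change beyond the scatter. With the trimethoxy pattern held fixed, methyl in place of chloro on an aromatic carbon gives a number 22 percentage points lower from compound 1 to compound 3 (beyond the scatter) and so separates the chloro compound from the methyl one. Nothing measured here explains either step. Still open, going by these compounds, is whether a hydroxyl or an amine at the methoxy position would behave alike, and whether bromo or fluoro in place of chloro would match compound 1.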